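This account rests on a few compounds, and the source may have more. Where it says the series, first, only, none or still open, it means among the compounds named here.

Notes on the series. In an ADME assay on HeLa cells (Homo sapiens) for cytotoxicity, read by MTT assay, with a stated time of 72 h (on this read-out higher numbers stand for weaker inhibition of growth and lower numbers for stronger inhibition of growth), compound 1 (`O=C(/C=C\c1ccccc1[N+](=O)[O-])N1N=C(c2ccncc2)OC1c1c[nH]c2ccccc12`) gives > 30 ug/mL, which is a limit of the assay and not a number. In this assay compound 2 (`O=C(/C=C\c1cccc(Cl)c1)N1N=C(c2ccncc2)OC1c1c[nH]c2ccccc12`) gives > 30 ug/mL, which is also a limit. The evidence so far is the limit of > 30 ug/mL in this assay, at which 2 of the 2 values shown sit, and no numeric value is available for either compound.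

Compound 3 (`O=C(/C=C\c1cccc(Br)c1)N1N=C(c2ccncc2)OC1c1c[nH]c2ccccc12`) differs from compound 2 by a single exchange: bromo in place of chloro on an aromatic carbon. This exchange turns 3-chlorophenyl into 3-bromophenyl.

Within the data shown here, only one measured step bears on this change, and it is a step that the two limits leave unreadable from compound 1 to compound 2. It therefore offers no size to carry forward. With compound 2 at > 30 ug/mL, no step beyond the scatter is expected in this assay, and no direction can be assigned. The expected change is a step that the limit leaves unreadable from compound 2 to compound 3. Compound 3 is estimated at 40 ug/mL, with an expected range from 20 ug/mL to 80 ug/mL, and the assay is expected to report only a limit.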

Compound 3, concentration for 50% growth inhibition: > 30 ug/mL
Compound 3 ended at the assay's limit (the forecaster's own chance of this, stated with the estimate: 85%); the middle value is on the limit's open side.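

Compound 1, compound 2 and compound 3 all stand at a limit in this assay, so none of the steps among them can be read, including bromo in place of chloro: the limit of > 30 ug/mL in this assay, at which 3 of the 3 values shown sit. The compounds shown leave open how strongly each inhibits growth, and whether changing the substituted phenyl group alters the read-out at all.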